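Compound 3: a larger group on an amine nitrogen

The compounds below may be only part of what the source reports. "The series", "measured", "known", "first", "only" and "open" are said of these compounds alone.

In a functional assay on MCF7 cells (Homo sapiens) for inhibition, read by MTT assay, with a stated time of 48 h (a higher number here means a weaker inhibitor, a lower number a stronger inhibitor), compound 2 `CCOC(=O)C1=C(N)Nc2[nH]nc(C)c2C1c1ccc(N(C)C)cc1` gives 5060 nM and compound 1 `CCOC(=O)C1=C(NN=C(C(C)=O)C(C)=O)Nc2[nH]nc(C)c2C1c1ccc(N(C)C)cc1` gives 9740 nM. Among the compounds with values here, these two values lie within the scatter of each other, so compound 2 stands level with the only other measured compound. Compound 3 `CCOC(=O)C1=C(N/C=N/c2ccc([N+](=O)[O-])cc2)Nc2[nH]nc(C)c2C1c1ccc(N(C)C)cc1` differs from compound 2 by a group of 11 heavy atoms (7 carbon, 2 nitrogen, 2 oxygen; one six-membered aromatic ring of carbon only) in place of a hydrogen atom, on an amine nitrogen. Within the data shown here, one measured step bears on this change: a 1.9-fold lower number from compound 1 to compound 2 (0.28 log units; within the scatter). That step exchanges a hydrogen atom and a larger group on an amine nitrogen, and it stays within the scatter. It is thin evidence, since the group in compound 1 has no ring and the group entering compound 3 has one. No step beyond the scatter is therefore expected in this assay, and the expected step is a 1.4-fold higher number from compound 2 to compound 3 (0.14 log units; within the scatter). For compound 3 the estimated value is 7000 nM, with an expected range from 2500 nM to 20000 nM.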

Compound 3, half-maximal inhibitory concentration: 58600 nM
Compound 3: the middle estimate sits 8.4-fold (0.92 log units) below what was measured, outside the stated range (above it).
By their numbers in this assay, from the lowest: compounds 2 and 1 (each within the scatter of the next); then compound 3.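

On this amine nitrogen, the earlier pair had shown no step beyond the scatter, yet in this assay the group of 11 heavy atoms brings a 12-fold higher number from compound 2 to compound 3 (1.06 log units; beyond the scatter) and so shows that a larger group here does not always leave the number in place. Set against the ring-free group of 8 heavy atoms, the same group gives a 6.0-fold higher number from compound 1 to compound 3 (0.78 log units; beyond the scatter) and thus the outcome depends on which group enters, not merely on the hydrogen atom being replaced. Nothing measured here accounts for this weakening.

The three compounds do not separate the six-membered aromatic ring from the nitro group it carries or from the rest of the entering group. Going by these compounds, how a plain phenyl, a benzyl or an acetyl group would stand on this amine nitrogen remains open.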